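Two weak cytotoxic compounds and one methoxy swap

This account rests on a few compounds, and the source may have more. Where it says the series, first, only, none or still open, it means among the compounds named here.

Values measured so far in a functional assay on K562 cells (Homo sapiens) for cytotoxicity, read by MTT assay, with a stated time of 72 h (a lower number here means a stronger inhibitor, a higher number a weaker inhibitor), are:

Compound 1 `COc1ccc(Nc2ccc3ccccc3n2)cc1` gives 30000 nM
Compound 2 `Cc1ccc(-c2ccnc(Nc3ccc(F)cc3)c2)cc1` gives 54000 nM

Both numbers are high, which in this assay means weak inhibition. Compound 2 (54000 nM) lies within the usual scatter of compound 1, so the two cannot be ranked against each other.

Compound 3 `COc1ccc(Nc2cc(-c3ccc(C)cc3)ccn2)cc1` matches compound 2 except at one place, where it has methoxy in place of fluoro on an aromatic carbon, para to a large group (methoxy in place of fluoro on an aromatic carbon). For the measured compounds named here, no measured pair shows this exchange on its own, so there is no direct guide to its effect. The nearest hint is indirect. Compound 1, which also carries a methoxy group on a different core, gives 30000 nM and so sits within the scatter of compound 2. A change beyond the scatter in this assay is therefore not expected. The estimated step is a 1.4-fold lower number from compound 2 to compound 3 (0.13 log units; within the scatter) and would stay within that scatter. For compound 3 the estimated value is 40000 nM (expected range 15000 nM to 100000 nM).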

Compound 3, half-maximal inhibitory concentration: 19000 nM
Compound 3: the middle estimate sits 2.1-fold (0.32 log units) above what was measured; low and high end bracket the measured number.
By their numbers in this assay, from the lowest: compounds 3, 1 and 2 (each within the scatter of the next, the first and the last beyond it).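

In this assay, for the compounds shown here, this is the first pair that differs in one place, and it gives a first reading of this position, on the aromatic ring para to a large group: the exchange of fluoro for methoxy brings a 2.8-fold lower number from compound 2 to compound 3 (0.45 log units; beyond the scatter). The position is therefore not silent, since a small exchange of a single substituent moves the number beyond the usual scatter, although the step is only modest and compound 3, at 19000 nM, remains a weak inhibitor. Nothing measured here accounts for why the number falls with methoxy in place of fluoro.

The compounds shown leave open how other groups at this place would compare, such as chloro, hydroxy, or a longer chain like ethoxy, and so whether the lower number is tied to methoxy itself or would appear with a range of substituents. A single pair also cannot say whether the same exchange would give a step of similar size on a different core, or whether it would hold in any other assay.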